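A few compounds are considered here, and "the series" means these few. Any claim that something is new, unique, unknown or untested is made for them only; others in the source may bear on it.

Working notes on the series. Three compounds have numbers in a functional assay (aorta) for inhibition, with Rattus norvegicus as the target; on this read-out lower numbers stand for stronger inhibition and higher numbers for weaker inhibition. Compound 1 `CC1(C)CN(C(=O)Nc2cccnc2)c2cc(C#N)ccc21` gives 1500000 nM, compound 2 `CC(C)(C)c1ccc(C#N)cc1NC(=O)Nc1ccccc1` gives 1700000 nM, and compound 3 `CC(C)(C)c1ccc(C#N)cc1/N=C(/NC#N)Nc1cccnc1` gives 1200000 nM. The three numbers lie within the usual scatter of one another, so compound 2 does not separate from compound 1 or from compound 3 in this assay. Compound 4 `CC(C)(C)c1ccc(C#N)cc1NC(=O)Nc1ccc(Cl)nc1` has not yet been measured. It differs from compound 2 by 6-chloropyridin-3-yl in place of phenyl on an amide-type nitrogen. For the measured compounds named here, no step between measured compounds covers this change, and the measured numbers give no lead for it in either direction. The step from compound 2 to compound 4 is expected to stay within the scatter, at a 1.4-fold lower number from compound 2 to compound 4 (0.15 log units; within the scatter). For compound 4 the estimate in this assay is 1200000 nM, with a range from 500000 nM to 3000000 nM.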

Compound 4, half-maximal inhibitory concentration: 1600000 nM
Beside the measured number, compound 4's estimate is 1.3-fold (0.12 log units) below it, within the range that was stated.
By their numbers in this assay, from the lowest: compounds 3, 1, 4 and 2 (each within the scatter of the next).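

In this assay, for the compounds shown here, 6-chloropyridin-3-yl in place of phenyl on an amide-type nitrogen gives a 1.1-fold lower number from compound 2 to compound 4 (0.03 log units; within the scatter) and is the only step that changes a single place. At this position, then, the entering ring nitrogen and chlorine leave the number within the scatter of the phenyl compound. No measured evidence bears on this result.

As far as these compounds go, it remains open whether an amine or a carboxylic acid on this ring would give a step beyond the scatter. From the compounds shown here alone, the effect of a longer chain in place of the ring is also open.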